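The source may report more compounds than this note shows. Statements on the series, on what has been measured and on what is new or still open speak of the compounds shown alone.

Measured compounds:
compound 1 `CCOC(=O)c1c(C)[nH]c(=O)c(C#N)c1-c1ccc(C)cc1` — 15900 nM
compound 2 `CCOC(=O)c1c(C)[nH]c(=O)c(C#N)c1-c1ccc(F)cc1` — 15400 nM
compound 3 `CCOC(=O)c1c(C)[nH]c(=O)c(C#N)c1-c1ccc(Br)cc1` — a limit of the assay, > 100000 nM

All three share one core and differ only in the substituent on the aryl ring. In a functional assay on A549 cells (Homo sapiens) for inhibition, read by MTT assay, with a stated time of 24 h (on this read-out lower numbers stand for stronger inhibition and higher numbers for weaker inhibition), compound 1 and compound 2 give numbers that are within the scatter of each other, as a 1.0-fold lower number from compound 1 to compound 2 (0.01 log units; within the scatter) shows. Compound 3, carrying the bromo group, is known only as a limit and sits at the limit of > 100000 nM in this assay, at which 1 of the 3 values shown sits; it is the weakest of the three, since an at least 6.2-fold higher number from compound 1 to compound 3 (0.79 log units; beyond the scatter) and an at least 6.4-fold higher number from compound 2 to compound 3 (0.81 log units; beyond the scatter) both lie beyond the scatter.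

Compound 4 `CCOC(=O)c1c(C)[nH]c(=O)c(C#N)c1-c1ccco1` has not been measured. It differs from compound 3 by furan-2-yl in place of 4-bromophenyl on an aromatic carbon. Among the compounds with values here, no measured step replaces the phenyl ring itself, so none bears directly on this change; what the measured steps show is that the bromo substituent alone raised the number beyond the limit, while methyl and fluoro gave numbers near each other. Removing the bromophenyl is therefore expected to bring the number back toward those of compound 1 and compound 2, with a lower number for compound 4 than for compound 3. Compound 4 is estimated to give 20000 nM, between 6000 nM and 100000 nM. That estimate means a step of an at least 5.0-fold lower number from compound 3 to compound 4 (0.69 log units; beyond the scatter) is expected.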

Compound 4, half-maximal inhibitory concentration: > 100000 nM
Compound 4: no number, only a limit; the forecaster's own chance of this, stated with the estimate: 30%; middle value at least 5.0-fold (0.69 log units) from the limit.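

In this assay compound 4 is known only as a limit: the limit of > 100000 nM in this assay, at which 2 of the 4 values shown sit. Within the data shown here, at this position, opposite the ring nitrogen, replacing the aryl ring itself gives an at least 6.4-fold higher number from compound 2 to compound 4 (0.81 log units; beyond the scatter) and an at least 6.2-fold higher number from compound 1 to compound 4 (0.79 log units; beyond the scatter), so the bromo group of compound 3 is no longer the only change that takes the number out of the measurable range. The step between compound 3 and compound 4 cannot be read, as both are limits.

The compounds shown leave open how far compound 3 and compound 4 lie from each other, and whether the plain phenyl group or a 4-chlorophenyl group at this position would give a number close to those of compound 1 and compound 2. They also leave open what a 4-aminophenyl group, a 4-carboxyphenyl group or an open alkyl chain would do here.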